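The compounds below may be only part of what the source reports. "The series", "measured", "known", "first", "only" and "open" are said of these compounds alone.

In a physicochemical assay for lipophilicity, at pH 7.4 (on this read-out higher numbers stand for higher lipophilicity and lower numbers for lower lipophilicity), compound 1 `O=C(NC1CC1)C1CCN(c2cnccc2-c2ccccc2)CC1` gives 2.5 and compound 2 `O=C(NC1CC1)C1CCN(c2cncnc2-c2ccccc2)CC1` gives 1.8, so compound 2 holds the lower of the two numbers, by a gap beyond the usual scatter. Compound 3 `CNC(=O)C1CCN(c2cncnc2-c2ccccc2)CC1` differs from compound 2 in one place, with methyl in place of cyclopropyl on an amide-type nitrogen. Among the compounds with values here, no measured pair shows this change on its own, so its size remains a judgement. A fall beyond the scatter is expected, with an estimated a number 0.50 log units lower from compound 2 to compound 3 (beyond the scatter). The estimated value in this assay for compound 3 is 1.3, within an expected range from 0.9 to 1.7.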

Compound 3, distribution coefficient: 1.4
Compound 3: middle estimate off by 0.10 log units, on the low side; the range from low to high includes it.
By their numbers in this assay, from the lowest: compound 3; then compound 2; then compound 1.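

Putting methyl in place of cyclopropyl on the amide-type nitrogen gives a number 0.40 log units lower from compound 2 to compound 3 (beyond the scatter) in this assay on an otherwise unchanged structure. Within the data shown here, this pair is the first to measure a change at this position, since compound 1 and compound 2 differ only in the core. Nothing given here accounts for the size of this step. On these data alone, whether the same step would appear on the core of compound 1 remains open. So does how a longer chain, such as propyl, or an amine-bearing chain on this nitrogen would compare with methyl and cyclopropyl.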